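This account rests on a few compounds, and the source may have more. Where it says the series, first, only, none or still open, it means among the compounds named here.

Compound 3 `CS(=O)(=O)N1CCC[C@H](c2csc(-c3ccccc3NC(=O)c3nc(Cl)c[nH]3)n2)C1` has been measured in an ADME assay on microsomes from liver (Homo sapiens) (on this read-out lower numbers stand for lower hepatic extraction and higher numbers for higher hepatic extraction), where compound 3 gives 0.91. On the bare numbers this is the second highest of three, but the gaps are small. Compound 2 `CS(=O)(=O)N1CCC[C@H](c2csc(-c3ccccc3NC(=O)c3nc(C#N)c[nH]3)n2)C1` gives 0.92 in this assay, and the step is a number 0.010 lower from compound 2 to compound 3 (within the scatter). Compound 1 `Cc1c[nH]c(C(=O)Nc2ccccc2-c2nc([C@H]3CCCN(S(C)(=O)=O)C3)cs2)n1` gives 0.83, and the step is a number 0.080 higher from compound 1 to compound 3 (within the scatter). The remaining step, a number 0.090 higher from compound 1 to compound 2 (within the scatter), is likewise within the scatter, so the three measured compounds cannot be put in any firm order on this read-out.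

Compound 4 `CS(=O)(=O)N1CCC[C@H](c2csc(-c3ccccc3NC(=O)c3nc4ccccc4[nH]3)n2)C1` has not yet been measured. It differs from compound 3 in one place: a group of 9 heavy atoms (7 carbon, 2 nitrogen; one five-membered aromatic ring with 2 hetero atoms, one six-membered aromatic ring of carbon only) in place of a group of 6 heavy atoms (3 carbon, 2 nitrogen, 1 chlorine; one five-membered aromatic ring with 2 hetero atoms), on a carbonyl carbon. Going by the values given here, none of the measured steps bears directly on this change; each of them swaps one small group on an aromatic carbon of the five-membered ring, whereas here the whole group on the carbonyl carbon is exchanged. The three measured values lie close together, and nothing among them points to a step beyond the scatter. Compound 4 is therefore expected to give 0.88 in this assay, within 0.74 to 0.97, which means an expected step of a number 0.030 lower from compound 3 to compound 4 (within the scatter).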

Compound 4, hepatic extraction ratio: 0.86
Compound 4: the middle estimate sits 0.020 above what was measured; low and high end bracket the measured number.
By their numbers in this assay, from the lowest: compounds 1, 4, 3 and 2 (each within the scatter of the next).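

The step on the carbonyl carbon is a much larger exchange than any seen before, yet this assay gives a number 0.050 lower from compound 3 to compound 4 (within the scatter) and a number 0.060 lower from compound 2 to compound 4 (within the scatter) as well as a number 0.030 higher from compound 1 to compound 4 (within the scatter) for the entry of 1H-benzimidazol-2-yl. The earlier compounds shown here only swapped one small group on an aromatic carbon of the five-membered ring, whereas this change adds a six-membered aromatic ring of carbon only and still leaves all four compounds within the scatter of one another. No measurement shown here offers a reason for this result.

Going by these compounds, it remains open whether any group on this carbonyl carbon can give a step beyond the scatter, for example a group carrying an amine or a carboxylic acid. Changes elsewhere on the shared core also remain untested in the compounds shown.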